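From pyridin-4-yl to pyridazin-3-yl on a carbonyl carbon

The compounds below may be only part of what the source reports. "The series", "measured", "known", "first", "only" and "open" are said of these compounds alone.

Of the compounds shown here, three that share one core have been measured in a physicochemical assay for solubility, measured as kinetic solubility, with a stated time of 1 h, at pH 7.4; a higher number here means a more soluble compound, a lower number a less soluble compound. Compound 1 `N#CCCC(=O)NC1=NN(c2ccc(Cl)c(Cl)c2)CC1` gives 39000 nM, compound 2 `O=C1CCCC(C(=O)NC2=NN(c3ccc(Cl)c(Cl)c3)CC2)N1` gives 416000 nM, and compound 3 `O=C(NC1=NN(c2ccc(Cl)c(Cl)c2)CC1)c1ccncc1` gives 9000 nM, the lowest number of the three. Compound 4 `O=C(NC1=NN(c2ccc(Cl)c(Cl)c2)CC1)c1cccnn1` has not yet been measured. It carries pyridazin-3-yl in place of pyridin-4-yl on a carbonyl carbon.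

All three measured steps changed this same place. The step of a 4.3-fold lower number from compound 1 to compound 3 (0.64 log units; beyond the scatter) was modest, while an 11-fold higher number from compound 1 to compound 2 (1.03 log units; beyond the scatter) and a 46-fold lower number from compound 2 to compound 3 (1.66 log units; beyond the scatter) were large. The number can therefore move a long way here, but none of these steps exchanges one six-membered aromatic ring for another, so they offer only loose guidance. As the entering group is again such a ring, a modest step is expected rather than a large one, and upward is the more likely direction, though the data do not settle this. The expected step is a 2.4-fold higher number from compound 3 to compound 4 (0.39 log units; beyond the scatter). For compound 4 the estimated value is 22000 nM, with an expected range of 6000 nM to 70000 nM.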

Compound 4, solubility: 67000 nM
Compound 4: middle estimate off by 3.0-fold (0.48 log units), on the low side; the measured number falls inside the stated range.
By their numbers in this assay, from the lowest: compound 3; then compounds 1 and 4 (each within the scatter of the next); then compound 2.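

In this assay, exchanging one six-membered aromatic ring for another at this position proves far from minor: the step is a 7.4-fold higher number from compound 3 to compound 4 (0.87 log units; beyond the scatter), although pyridin-4-yl and pyridazin-3-yl have the same count of heavy atoms and differ by one ring nitrogen. The new ring still falls short of the 6-oxopiperidin-2-yl group, with a 6.2-fold lower number from compound 2 to compound 4 (0.79 log units; beyond the scatter), while a 1.7-fold higher number from compound 1 to compound 4 (0.24 log units; within the scatter) leaves it indistinguishable from the 2-cyanoethyl chain. Nothing shown gives a reason for the step from pyridin-4-yl to pyridazin-3-yl.

As far as these compounds go, what a pyrimidin-5-yl or pyrazin-2-yl ring would give on this carbonyl carbon remains open, as does the effect of an amine on the pyridazin-3-yl ring. All four compounds share one core, so whether this step would carry over to another core is also unknown.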